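Removing the methoxy that replaced the tetrazolyl substituent

A few compounds are considered here, and "the series" means these few. Any claim that something is new, unique, unknown or untested is made for them only; others in the source may bear on it.

The series shares one core, carried by compound 1 `COc1ccc(-n2nnnc2C(F)(F)F)cc1[C@H]1COCC2(C1)OCCN[C@H]2c1ccc(F)cc1` and compound 2 `COc1ccc(OC)c([C@H]2COCC3(C2)OCCN[C@H]3c2ccc(F)cc2)c1`. Among the measured compounds shown here, in an assay on CHO cells for displacement of a labelled ligand from Substance-P receptor (Homo sapiens) (on this read-out lower numbers stand for stronger inhibition and higher numbers for weaker inhibition), compound 1 gives 0.1 nM, while compound 2 gives 16 nM, the higher of the two numbers known so far; the step of a 160-fold higher number from compound 1 to compound 2 (2.20 log units; beyond the scatter) shows how much that position matters. Compound 3 `COc1ccccc1[C@H]1COCC2(C1)OCCN[C@H]2c1ccc(F)cc1` follows with hydrogen in place of methoxy on an aromatic carbon. For the measured compounds named here, no measured step covers this exact change, and the only step at this position is a 160-fold higher number from compound 1 to compound 2 (2.20 log units; beyond the scatter), which is large. For compound 3 a smaller further loss is expected, estimated as a 2.5-fold higher number from compound 2 to compound 3 (0.40 log units; beyond the scatter). Compound 3 is thus estimated at 40 nM, within 12 nM to 130 nM.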

Compound 3, half-maximal inhibitory concentration: 13 nM
Compound 3: middle estimate off by 3.1-fold (0.49 log units), on the high side; the measured number falls inside the stated range.
By their numbers in this assay, from the lowest: compound 1; then compounds 3 and 2 (each within the scatter of the next).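

In this assay, methoxy and hydrogen at this position, para to a methoxy group, cannot be told apart (a 1.2-fold lower number from compound 2 to compound 3 (0.09 log units; within the scatter)). The large loss persists with hydrogen (a 130-fold higher number from compound 1 to compound 3 (2.11 log units; beyond the scatter)), so it follows the departure of the 5-(trifluoromethyl)-1H-tetrazol-1-yl substituent, whichever of these two small replacements enters. No evidence at hand bears on why this substituent matters.

Going by these compounds, how much of the difference rests on the trifluoromethyl part of that substituent stays open. So does the outcome with other groups at this position, such as a nitrile or a carboxylic acid.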